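Aryl exchange from compound 3 to compound 4

This account rests on a few compounds, and the source may have more. Where it says the series, first, only, none or still open, it means among the compounds named here.

Measured in a functional assay on HL-60 cells (Homo sapiens) for inhibition; a higher number here means a weaker inhibitor, a lower number a stronger inhibitor:
- compound 1 `OC[C@H]1OC(n2cnc3c(-c4ccoc4)ncnc32)[C@H](O)[C@@H]1O` gives 3300 nM
- compound 2 `Cc1ccsc1-c1ncnc2c1ncn2C1O[C@H](CO)[C@@H](O)[C@H]1O` gives 4500 nM
- compound 3 `Cc1csc(-c2ncnc3c2ncn3C2O[C@H](CO)[C@@H](O)[C@H]2O)c1` gives 5600 nM

Compound 3 stands at 5600 nM, not separated from the other two: the steps are a 1.2-fold higher number from compound 2 to compound 3 (0.09 log units; within the scatter) and a 1.7-fold higher number from compound 1 to compound 3 (0.23 log units; within the scatter). The remaining step, a 1.4-fold higher number from compound 1 to compound 2 (0.13 log units; within the scatter), is also within the scatter.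

Compound 4 `OC[C@H]1OC(n2cnc3c(-c4ccc(F)cc4)ncnc32)[C@H](O)[C@@H]1O` carries 4-fluorophenyl in place of 4-methylthiophen-2-yl on an aromatic carbon. The measured steps only exchange furan-3-yl, 3-methylthiophen-2-yl and 4-methylthiophen-2-yl, so they bear on this change only indirectly. No step beyond the scatter is expected in this assay, though the range stays wide. The expected step is a 1.1-fold higher number from compound 3 to compound 4 (0.03 log units; within the scatter). For compound 4 the estimated value is 6000 nM, with an expected range of 2000 nM to 20000 nM.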

Compound 4, half-maximal inhibitory concentration: 6300 nM
Estimate against measurement, compound 4: 1.1-fold (0.02 log units) below; the range from low to high includes it.
By their numbers in this assay, from the lowest: compounds 1, 2, 3 and 4 (each within the scatter of the next).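

In this assay this position takes a six-membered aromatic ring of carbon only as well as the five-membered aromatic rings with a hetero atom. The exchange for 4-fluorophenyl gives a 1.1-fold higher number from compound 3 to compound 4 (0.05 log units; within the scatter) and also a 1.4-fold higher number from compound 2 to compound 4 (0.15 log units; within the scatter) and a 1.9-fold higher number from compound 1 to compound 4 (0.28 log units; within the scatter) with no step beyond the scatter. Neither ring size nor the ring hetero atom separates these four compounds here. As far as these compounds go, whether an amine or a carboxylic acid on the aryl ring would move the number beyond the scatter stays open. Nothing at hand explains the flat series.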